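Series solubility notes: compound 3 against compound 2

This account rests on a few compounds, and the source may have more. Where it says the series, first, only, none or still open, it means among the compounds named here.

Going by the values given here, compound 2 `COc1cccc(CNCCCNc2ccnc3cc(Cc4cccc(C(F)(F)F)c4)ccc23)c1O` is the less soluble of the two compounds measured so far in a physicochemical assay for solubility, with a stated time of 18 h, at pH 7.4 (on this read-out lower numbers stand for lower solubility and higher numbers for higher solubility), where compound 2 gives 4200 nM. Among the compounds with values here, compound 1 `COc1ccc(Oc2ccc3c(NCCCNCc4cccc(OC)c4O)ccnc3c2)cc1` carries 4-methoxyphenoxy on the aromatic carbon where compound 2 carries 3-(trifluoromethyl)benzyl, and in this assay compound 1 gives 14500 nM; the single measured step is a 3.5-fold lower number from compound 1 to compound 2 (0.54 log units; beyond the scatter). Compound 3 `COc1cccc(CNCCCNc2ccnc3cc(Cc4cc(C)cc(C)c4)ccc23)c1O` keeps the core of compound 2 and differs only within the benzyl group: 3,5-dimethylphenyl in place of 3-(trifluoromethyl)phenyl on a saturated chain carbon bound to an aromatic carbon. Within the data shown here, no measured step touches this kind of change: the one known step exchanges the whole group on the aromatic carbon, not a substituent on the phenyl ring of a benzyl group, so it offers no direct guide. Both the leaving and the entering group carry no hydrogen-bond donors and no hydrogen-bond acceptors, and the ring count is unchanged, so a step within the scatter is expected, a 1.1-fold lower number from compound 2 to compound 3 (0.02 log units; within the scatter). Compound 3 is therefore estimated at 4000 nM in this assay, with a range from 1500 nM to 11000 nM.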

Compound 3, solubility: 4200 nM
Compound 3: middle estimate off by 1.1-fold (0.02 log units), on the low side; measured number inside the range.
By their numbers in this assay, from the lowest: compounds 2 and 3 (each within the scatter of the next); then compound 1.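

In this assay, going by these compounds alone, 3,5-dimethylphenyl in place of 3-(trifluoromethyl)phenyl on a saturated chain carbon bound to an aromatic carbon gives no change at the digits printed from compound 2 to compound 3 (within the scatter), the first reading of a change within the benzyl group rather than an exchange of the whole group on the aromatic carbon. With 3,5-dimethylbenzyl in place of 4-methoxyphenoxy on an aromatic carbon, the series shows a 3.5-fold lower number from compound 1 to compound 3 (0.54 log units; beyond the scatter), which now stands as a second benzyl example alongside a 3.5-fold lower number from compound 1 to compound 2 (0.54 log units; beyond the scatter). No measured information on what lies behind these numbers is available.

On these data alone, both phenyl rings compared at this position carry only carbon or fluorine substituents and have no hydrogen-bond donors or acceptors, so it remains open whether an amine or a carboxylic acid on that ring would leave the number in this assay unchanged. Also open, as far as these compounds go, is whether the difference from compound 1 follows the oxygen link or the methoxy group, a question that a pair such as 3-(trifluoromethyl)phenoxy and 4-methoxybenzyl on the same aromatic carbon could separate.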